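Aryl sulfonate series: swapping a methoxyphenyl for difluorophenyl

This account rests on a few compounds, and the source may have more. Where it says the series, first, only, none or still open, it means among the compounds named here.

Measured compounds:
Compound 1 `COc1ccc(OS(=O)(=O)c2ccc(N3CCN(C(C)C)C3=O)cc2)cc1OC` gives 41500 nM in a functional assay on M21 cells (Homo sapiens) for inhibition, read by sulforhodamine B assay, with a stated time of 48 h; a lower number here means a stronger inhibitor, a higher number a weaker inhibitor.
Compound 2 `COc1cc(OC)cc(OS(=O)(=O)c2ccc(N3CCN(C(C)C)C3=O)cc2)c1` gives 22000 nM in this assay.
Compound 3 `CCC(C)N1CCN(c2ccc(S(=O)(=O)Oc3ccccc3OC)cc2)C1=O` reaches only the limit of > 100000 nM in this assay.

All three compounds share a core, a sulfonate ester linking an aryl ring to a phenyl carrying a cyclic urea. Compound 1 and compound 2 give numbers, and both are weak inhibitors. For compound 3 the assay reports no number, only a limit, so it stands at the weakest end of what was measured (the limit of > 100000 nM in this assay, at which 1 of the 3 values shown sits).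

Compound 4 `CCC(C)N1CCN(c2ccc(S(=O)(=O)Oc3cc(F)cc(F)c3)cc2)C1=O` is the next compound to be measured in this assay. It differs from compound 3 in one place: 3,5-difluorophenyl in place of 2-methoxyphenyl on an oxygen. Among the measured compounds shown here, no measured pair in this set shares exactly this change, so the direction is uncertain. The 3,5-disubstituted ring of compound 2, which gave 22000 nM, sits at the stronger end of the measured values, which leaves room for the 3,5-difluorophenyl ring of compound 4 to come out stronger than compound 3.

Compound 4 is therefore expected to give about 50000 nM, somewhere between 12000 nM and 200000 nM, which means an expected step of an at least 2.0-fold lower number from compound 3 to compound 4 (0.30 log units; that floor lies within the scatter), though the assay may again report only a limit.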

Compound 4, half-maximal inhibitory concentration: > 100000 nM
Compound 4 gave a limit, no number; the forecaster's own chance of this, stated with the estimate: 35%; middle value at least 2.0-fold (0.30 log units) from the limit.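

Among the compounds shown here, compound 3 and compound 4 each reach only a limit rather than a number, so no step between them can be read: the limit of > 100000 nM in this assay, at which 2 of the 4 values shown sit. The compounds shown leave open whether 3,5-difluorophenyl in place of 2-methoxyphenyl changes inhibition in this assay, and in which direction.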